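Substituent swap at the anilino aryl of compound 1

The source may hold more compounds than are shown below. What is called first, only, known or untested is meant among the compounds shown, and "the series" means these compounds.

Measured compounds:
compound 1, `COc1ccc(N/C=C\C(=O)c2nc(-c3ccc(F)cc3)n3ccccc23)cc1`, 15700 nM
compound 2, `O=C(/C=C\Nc1ccc2[nH]ccc2c1)c1nc(-c2ccc(C(F)(F)F)cc2)n2ccccc12`, 5190 nM

Notes on the series. In a functional assay on BT-474 cells (Homo sapiens) for cytotoxicity, read by MTT assay, with a stated time of 48 h (on this read-out higher numbers stand for weaker inhibition and lower numbers for stronger inhibition), compound 1 gives 15700 nM, the highest number of the two measured; its nearest neighbour, compound 2, gives 5190 nM, and the gap between the two values is beyond the scatter. Compound 2 differs from compound 1 in more than one place, so the two values are only set side by side here and no single change is read out of them.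

The next compound, compound 3, `O=C(/C=C\Nc1ccc(Cl)cc1)c1nc(-c2ccc(F)cc2)n2ccccc12`, is to be measured in this assay. It keeps the shared core of compound 1 and changes only one place: chloro in place of methoxy on an aromatic carbon. Among the measured compounds shown here, no measured pair isolates this change, so the size of its effect is not known from data. The expectation is a modest lowering of the number, a 1.6-fold lower number from compound 1 to compound 3 (0.20 log units; within the scatter), which may well fall within the scatter rather than beyond it. For compound 3 the estimate in this assay is 10000 nM, with a range from 3000 nM to 35000 nM.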

Compound 3, half-maximal inhibitory concentration: 7030 nM
Compound 3: the middle estimate sits 1.4-fold (0.15 log units) above what was measured; the measured number falls inside the stated range.
By their numbers in this assay, from the lowest: compounds 2 and 3 (each within the scatter of the next); then compound 1.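

Methoxy to chloro on the aromatic carbon para to a large group gives a 2.2-fold lower number from compound 1 to compound 3 (0.35 log units; beyond the scatter) in this assay, and this is the only step in the series that changes one place while the rest of the structure stays fixed. The position is therefore not silent in this cell read-out: one exchange here, from a group with one hydrogen-bond acceptor and two heavy atoms to a single chlorine, is enough to move the number beyond the scatter, although the step is modest. No evidence is at hand to explain the step, and this single pair gives no account of what drives it.

As far as these compounds go, one exchange fixes no trend at this position, so it remains open how the number would respond to a hydrogen, a fluoro, an amine, a carboxylic acid or a longer chain such as ethoxy in the same place. From the compounds shown here alone, it is also open whether chloro in place of methoxy gives a step of similar size when the trifluoromethyl group of compound 2 stands on the other aryl ring.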